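Isopropylamine in Place of the Propargyl Group

This account rests on a few compounds, and the source may have more. Where it says the series, first, only, none or still open, it means among the compounds named here.

Of the compounds shown here, three have been measured in an assay on isolated protein for inhibition of Amine oxidase [flavin-containing] A (Rattus norvegicus); on this read-out lower numbers stand for stronger inhibition and higher numbers for weaker inhibition. Compound 1 `CC#CCN(C)Cc1cc2cc(O)ccc2n1C` gives 5.7 nM, compound 2 `C#CCN(C)Cc1cn(Cc2ccccc2)c2ccccc12` gives 160000 nM and compound 3 `Cn1c(CNCc2ccccc2)cc2ccccc21` gives 34000 nM. On these numbers compound 2 stands highest of the three: compound 3 is its nearest neighbour, with a lower number that lies beyond the scatter, and compound 1 is furthest from it, far lower again.

Compound 4 `CC(C)NCc1cn(Cc2ccccc2)c2ccccc12` has not yet been measured in this assay . It differs from compound 2 in one place: isopropylamino in place of methyl(propargyl)amino on a saturated chain carbon bound to an aromatic carbon. In words, isopropylamino replaces methyl(propargyl)amino on a saturated chain carbon bound to an aromatic carbon. Among the measured compounds shown here, no measured pair shows this exact change, so the size of the step can only be gauged from the spread of the numbers already seen.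

Compound 3, which also carries one hydrogen-bond donor at its amine and gives 34000 nM, is the closest guide among the measured compounds. The step from compound 2 to compound 4 is therefore expected to be small, a 2.0-fold lower number from compound 2 to compound 4 (0.30 log units; within the scatter), and may not go beyond the scatter. Compound 4 is estimated at 80000 nM in this assay , with a range from 15000 nM to 400000 nM.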

Compound 4, inhibition constant: 133000 nM
For compound 4 the middle estimate is 1.7-fold (0.22 log units) below the measured one; low and high end bracket the measured number.
By their numbers in this assay, from the lowest: compound 1; then compound 3; then compounds 4 and 2 (each within the scatter of the next).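

In this assay, among the compounds shown here, the step is a 1.2-fold lower number from compound 2 to compound 4 (0.08 log units; within the scatter), so the first pair that differs in one place cannot be told apart on this read-out. On a saturated chain carbon bound to an aromatic carbon of this core, methyl(propargyl)amino and isopropylamino therefore read alike, even though the exchange removes the triple bond and brings in a hydrogen-bond donor. For the compounds shown here, both compounds have numbers far up the measured range, so this pair shows only that the exchange does not separate two weak inhibitors, and nothing available accounts for this result.

The compounds shown leave open whether a simple dimethylamino group, a primary amine or a longer chain on that nitrogen would give a number beyond the scatter from these two on the same core. Going by these compounds alone, they also leave open whether the same exchange would matter as little on the core of compound 1, which gives 5.7 nM, since no pair here tests the exchange where the number is low.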